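A Cyano Group on the Cyclopentyl Compound

The source may hold more compounds than are shown below. What is called first, only, known or untested is meant among the compounds shown, and "the series" means these compounds.

In a physicochemical assay for solubility, in phosphate buffer, measured as kinetic solubility, at pH 7.4 (on this read-out lower numbers stand for lower solubility and higher numbers for higher solubility), compound 2 (`O=c1[nH]ccc2c(NC3CCCC3)ncnc12`) gives 318000 nM and lies within the scatter of compound 1 (`O=c1[nH]ccc2c(NC3CCCCC3)ncnc12`), which gives 225000 nM in the same test. Compound 3 (`N#C[C@H]1CCC[C@H]1Nc1ncnc2c(=O)[nH]ccc12`) carries cyano in place of hydrogen on a saturated ring carbon. Among the measured compounds shown here, the only measured step is a 1.4-fold higher number from compound 1 to compound 2 (0.15 log units; within the scatter) with cyclopentyl in place of cyclohexyl, and it lies within the scatter. For the measured compounds named here, no measured step adds cyano, so the data offer no direct guide. In this assay the expected step is a 1.3-fold lower number from compound 2 to compound 3 (0.10 log units; within the scatter) and thus none beyond the scatter. Compound 3 is estimated at 250000 nM with a range from 100000 nM to 450000 nM in this measurement.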

Compound 3, solubility: 104000 nM
Compound 3: the middle estimate sits 2.4-fold (0.38 log units) above what was measured; measured number inside the range.
By their numbers in this assay, from the lowest: compound 3; then compounds 1 and 2 (each within the scatter of the next).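

Cyano in place of hydrogen on a saturated ring carbon, next to the ring atom that bears a large group, changes the number in this assay (a 3.1-fold lower number from compound 2 to compound 3 (0.49 log units; beyond the scatter)). Among the compounds shown here, this is the first step that lies beyond the scatter, which the change from cyclohexyl to cyclopentyl did not reach. Nothing available here accounts for the step.

Going by these compounds, whether an amine or a carboxylic acid on this same carbon would give a step of similar size stays open. So does whether cyano would have the same result on the cyclohexyl ring of compound 1.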